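Notes on two esters and a demethylated analogue

The compounds below may be only part of what the source reports. "The series", "measured", "known", "first", "only" and "open" are said of these compounds alone.

Measured so far:
compound 1 `COCCNC(=O)c1[nH]cc(C(=O)O[C@@H](C)C(C)(C)C)c1C`: 31.6 nM
compound 2 `COCCNC(=O)c1[nH]c(C)c(C(=O)OC2CC3CCC2C3)c1C`: 316 nM

Both numbers come from an assay on CHO cells for inhibition of metabotropic glutamate receptor 1 (Homo sapiens); on this read-out higher numbers stand for weaker inhibition and lower numbers for stronger inhibition. Going by the values given here, compound 2 has the higher of the two numbers; its only neighbour, compound 1, lies lower by a gap beyond the scatter. Compound 3 `COCCNC(=O)c1[nH]cc(C(=O)OC2CC3CCC2C3)c1C` is not yet measured. It keeps the ester of compound 2 and differs from it by hydrogen in place of methyl on an aromatic carbon next to the ring nitrogen. Because compound 1, which also carries hydrogen there, gives 31.6 nM, a downward step is expected, beyond the scatter, of about a 2.4-fold lower number from compound 2 to compound 3 (0.39 log units; beyond the scatter). Compound 3 is estimated at 130 nM, between 40 nM and 450 nM.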

Compound 3, half-maximal inhibitory concentration: 158 nM
Beside the measured number, compound 3's estimate is 1.2-fold (0.08 log units) below it, and the stated range covers the measured number.
By their numbers in this assay, from the lowest: compound 1; then compounds 3 and 2 (each within the scatter of the next).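

In this assay, hydrogen in place of methyl on the aromatic carbon next to the ring nitrogen gives a 2.0-fold lower number from compound 2 to compound 3 (0.30 log units; within the scatter), so the two groups are not separated at this position. With hydrogen held there, changing only the group on the oxygen next to a carbonyl group gives a 5.0-fold higher number from compound 1 to compound 3 (0.70 log units; beyond the scatter), and this change is resolved in the read-out. As far as these compounds go, how ethyl at this position, or a carboxylic acid in place of the ester, would read remains open. Nothing available bears on the cause of either step.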